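The compounds below may be only part of what the source reports. "The series", "measured", "known", "first", "only" and "open" are said of these compounds alone.

Measured compounds:
compound 1 `Cc1ccc2c(c1)CC(CCN(C)C)=C2C(C)c1ccccn1` with 1450 nM
compound 2 `CC(C1=C(CCN2CCCCC2)Cc2ccccc21)c1ccccn1` with 2340 nM

Of the compounds shown here, two have been measured in an assay on CHO-K1 cells for binding affinity to muscarinic acetylcholine receptor M5 (Homo sapiens); a lower number here means a stronger inhibitor, a higher number a weaker inhibitor. Compound 1 gives 1450 nM in this assay, and compound 2 gives 2340 nM in this assay. The two numbers lie within the usual scatter of each other, so neither compound stands apart from the other on these data.

Compound 3 `CCN(CC)CCC1=C(C(C)c2ccccn2)c2ccccc2C1` has not yet been measured. It differs from compound 2 in one place: diethylamino in place of piperidin-1-yl on a saturated chain carbon, two bonds along the chain from a double-bonded ring carbon. No step between two measured compounds that differ in this way is available, so the expectation rests only on the two numbers shown and on the nature of the change, which replaces one basic amine by another of nearly the same size. A step of this kind is expected to stay within the scatter, with no clear direction. Compound 3 is therefore expected to give about 2000 nM in this assay, with a range from 800 nM to 5000 nM. This expected step, a 1.2-fold lower number from compound 2 to compound 3 (0.07 log units; within the scatter), is estimated to be small.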

Compound 3, inhibition constant: 2090 nM
Beside the measured number, compound 3's estimate is 1.0-fold (0.02 log units) below it, within the range that was stated.
By their numbers in this assay, from the lowest: compounds 1, 3 and 2 (each within the scatter of the next).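

Within the data shown here, the first step between two compounds that differ in one place, read in this assay, is a 1.1-fold lower number from compound 2 to compound 3 (0.05 log units; within the scatter), on exchanging piperidin-1-yl for diethylamino on a saturated chain carbon, two bonds along the chain from a double-bonded ring carbon. At this position, therefore, the six-membered ring of piperidin-1-yl can give way to the open diethylamino group, with its one heavy atom fewer, without a step beyond the scatter. Nothing measured on how these compounds behave offers an account of this result.

From the compounds shown here alone, what remains open is whether any change at this position can move the number beyond the scatter, as this single exchange swaps one amine without a ring for one with a ring and so tests only a narrow kind of change. A primary amine, a morpholine ring or a carboxylic acid in place of the diethylamino group, or a longer chain carrying the same amine, could each show how far this position tolerates change in this assay.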